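A few compounds are considered here, and "the series" means these few. Any claim that something is new, unique, unknown or untested is made for them only; others in the source may bear on it.

In a functional assay on HeLa cells (Homo sapiens) for antiproliferative activity, read by CCK-8 assay, with a stated time of 72 h, tested at 8 uM (on this read-out higher numbers stand for a stronger effect at the one concentration tested and lower numbers for a weaker effect), compound 1 `Nc1ccccc1NC(=O)c1ccc(CSC(=S)N2CCN(Cc3ccncc3)CC2)cc1` gives 72.9%, while compound 2 `Cc1ccc(N2CCN(C(=S)SCc3ccc(C(=O)Nc4ccccc4N)cc3)CC2)cc1` gives 24%. Compound 2 therefore stands lowest of the two numbers measured, separated from compound 1 by a step beyond the scatter. Compound 3 `Nc1ccccc1NC(=O)c1ccc(CSC(=S)N2CCN(c3ncccn3)CC2)cc1` differs from compound 2 in one place: pyrimidin-2-yl in place of 4-methylphenyl on an amine nitrogen in a ring. Among the measured compounds shown here, the only measured step that bears on this change is a number 48.9 percentage points lower from compound 1 to compound 2 (beyond the scatter), a large drop produced by an exchange at the same ring nitrogen. The entering pyrimidin-2-yl again carries two hydrogen-bond acceptors, as the (pyridin-4-yl)methyl of compound 1 did, but like the 4-methylphenyl of compound 2 it is an aromatic ring attached directly to the ring nitrogen. A partial recovery is therefore expected, a step of a number 18 percentage points higher from compound 2 to compound 3 (beyond the scatter). Compound 3 is estimated to give 42% in this assay, with a plausible range from 20% to 65%.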

Compound 3, a percentage reported as inhibition, at one concentration (the size of the read-out at that concentration, not a potency): 73.9%
Estimate against measurement, compound 3: 31.9 percentage points below; the measured number lies above the stated range.
By their numbers in this assay, from the lowest: compound 2; then compounds 1 and 3 (each within the scatter of the next).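

The step of a number 49.9 percentage points higher from compound 2 to compound 3 (beyond the scatter) in this assay shows that the low number of compound 2 does not extend to every aromatic ring attached directly to the amine nitrogen in the ring. The step of a number 1 percentage points higher from compound 1 to compound 3 (within the scatter) places pyrimidin-2-yl level with (pyridin-4-yl)methyl on this read-out, and among these three compounds only 4-methylphenyl, the ring of carbon only, stands apart. Nothing available here explains this difference between the rings. The compounds shown leave open whether the gain follows the ring nitrogens or the loss of the methyl group, which an unsubstituted phenyl or a pyridin-2-yl group at this nitrogen would help separate. They also leave open how a benzyl group or a simple alkyl chain would fare here.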